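Aryl group swaps on a shared core: notes on compound 4

The source may report more compounds than this note shows. Statements on the series, on what has been measured and on what is new or still open speak of the compounds shown alone.

Measured in a functional assay on KB cells (Homo sapiens) for cytotoxicity; on this read-out higher numbers stand for an effect only at larger amounts of compound and lower numbers for an effect already at smaller amounts:
- compound 1 `COC1=C(C)C(=O)/C(=C(O)/C=C/c2ccc(Br)cc2)C(=O)C1(C)C`: 1.7 ug/mL
- compound 2 `COC1=C(C)C(=O)/C(=C(O)/C=C/c2ccccc2OC)C(=O)C1(C)C`: 3.3 ug/mL
- compound 3 `COC1=C(C)C(=O)/C(=C(O)/C=C/c2ccc(O)cc2)C(=O)C1(C)C`: 3.8 ug/mL

Compound 2 lies within the scatter of both other compounds: a 1.9-fold higher number from compound 1 to compound 2 (0.29 log units; within the scatter) and a 1.2-fold higher number from compound 2 to compound 3 (0.06 log units; within the scatter). Compound 4 `CCc1ccc(/C=C/C(O)=C2/C(=O)C(C)=C(OC)C(C)(C)C2=O)cc1` brings the change (4-ethylphenyl in place of 2-methoxyphenyl on a double-bonded chain carbon bound to a double-bonded chain carbon), with 4-ethylphenyl in place of 2-methoxyphenyl. For the measured compounds named here, no measured compound carries 4-ethylphenyl. Both aryl swaps starting or ending at compound 2 stayed small, and only a 2.2-fold higher number from compound 1 to compound 3 (0.35 log units; beyond the scatter) passed the scatter, modestly. No step beyond the scatter is therefore expected in this assay. The estimate means a 1.3-fold lower number from compound 2 to compound 4 (0.10 log units; within the scatter), as an expected step. Compound 4 is expected at 2.6 ug/mL, with an estimated range of 1.3 ug/mL to 5.2 ug/mL.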

Compound 4, concentration for half-maximal effect: 6.9 ug/mL
The estimate for compound 4 lay 2.7-fold (0.42 log units) below the measured number; measured number above the stated range.
By their numbers in this assay, from the lowest: compounds 1, 2, 3 and 4 (each within the scatter of the next, the first and the last beyond it).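

In this assay, for the compounds shown here, 4-ethylphenyl is the first group at this position to move the number beyond the scatter relative to the 2-methoxyphenyl of compound 2 (a 2.1-fold higher number from compound 2 to compound 4 (0.32 log units; beyond the scatter)). Ethyl in place of hydroxy stays within the scatter (a 1.8-fold higher number from compound 3 to compound 4 (0.26 log units; within the scatter)). Ethyl in place of bromo on the same aromatic carbon gives the widest gap in the series (a 4.1-fold higher number from compound 1 to compound 4 (0.61 log units; beyond the scatter)).

No supporting data bear on the reason for these steps. On these data alone, how an amine, a carboxylic acid or a longer chain such as butyl on that aromatic carbon would compare remains open.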